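A few compounds are considered here, and "the series" means these few. Any claim that something is new, unique, unknown or untested is made for them only; others in the source may bear on it.

The account follows three sulfonamides already measured in an assay for inhibition of liver carboxylesterase 1 (Homo sapiens), read by spectrophotometry (on this read-out lower numbers stand for stronger inhibition and higher numbers for weaker inhibition), and a fourth that has not yet been tested. Compound 1, `O=C(O)c1ccc(S(=O)(=O)Nc2ccc(NS(=O)(=O)c3ccc(F)cc3)cc2)cc1`, carries a carboxy group on one outer ring. In this assay compound 1 gives > 100000 nM, which is a limit of the assay and not a number. Compound 2, `Cc1c(C)c(NS(=O)(=O)c2ccc(Br)cc2)c(C)c(C)c1NS(=O)(=O)c1ccc(Br)cc1`, carries methyl groups on the central ring and a bromo group on each outer ring. In this assay compound 2 likewise reaches only the limit, > 100000 nM. Compound 3, `O=S(=O)(Nc1ccc(NS(=O)(=O)c2cccc(Br)c2)cc1)c1cccc(Br)c1`, carries a bromo group on each outer ring. In this assay compound 3 again returns the limit, > 100000 nM. Compound 1 therefore stands exactly where its two companions stand, at the limit of > 100000 nM in this assay, at which 3 of the 3 values shown sit.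

The new compound, compound 4, `O=S(=O)(Nc1ccc(NS(=O)(=O)c2ccc(F)cc2)cc1)c1ccc(F)cc1`, differs from compound 1 in one place: fluoro in place of carboxy on an aromatic carbon. Going by the values given here, no step between two measured compounds exists to show what such a change does here. Among the compounds with values here, with every value so far a limit, no direction can be read, and the step is expected to be a number no higher from compound 1 to compound 4 (the limit leaves the size open), none beyond the scatter, because the limit of > 100000 nM in this assay, at which 3 of the 3 values shown sit, holds all three measured compounds. Compound 4 is estimated at 100000 nM, with a range from 30000 nM to 300000 nM, and the assay is expected most likely to report only a limit again.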

Compound 4, inhibition constant: > 100000 nM
Compound 4 gave a limit, no number; the forecaster's own chance of this, stated with the estimate: 80%; the middle value sits exactly at the limit.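

In this assay compound 4 returns > 100000 nM, which is a limit of the assay and not a number. Compound 1 also stands at a limit, so no step can be read between compound 1 and compound 4. All the compounds shown sit together: the limit of > 100000 nM in this assay, at which 4 of the 4 values shown sit. They leave open what fluoro in place of carboxy does, and whether any compound of this kind gives a measurable number in this assay.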